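Swapping the ethylcarbamoyl for hydroxymethyl on the sugar ring

A few compounds are considered here, and "the series" means these few. Any claim that something is new, unique, unknown or untested is made for them only; others in the source may bear on it.

The measured compounds:
compound 1, `CCNC(=O)[C@H]1O[C@@H](n2cnc3c(NC)nc(-n4ccnn4)nc32)[C@H](O)[C@@H]1O`, 590 nM
compound 2, `CNc1nc(-n2cc(CC3CCCCC3)nn2)nc2c1ncn2[C@@H]1O[C@H](CO)[C@@H](O)[C@H]1O`, 1430 nM
compound 3, `CCNC(=O)[C@H]1O[C@@H](n2cnc3c(NC)nc(-n4cc(CC5CCCC5)nn4)nc32)[C@H](O)[C@@H]1O`, 1250 nM

In an assay on CHO cells for displacement of a labelled ligand from adenosine receptor A1 (Homo sapiens) (a lower number here means a stronger inhibitor, a higher number a weaker inhibitor), compound 3 gives 1250 nM, the second highest of the three numbers. Among the measured compounds shown here, it is within the scatter of compound 2, which gives 1430 nM, and the one step that reaches it, a 2.1-fold higher number from compound 1 to compound 3 (0.33 log units; beyond the scatter), is modest and lies beyond the scatter.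

Compound 4, `CNc1nc(-n2cc(CC3CCCC3)nn2)nc2c1ncn2[C@@H]1O[C@H](CO)[C@@H](O)[C@H]1O`, differs from compound 3 in one place: hydroxymethyl in place of ethylcarbamoyl on a saturated ring carbon. For the measured compounds named here, no measured pair isolates this change: compound 1 and compound 2 differ in two places, so their values say nothing clean about it. Going by the values given here, the only guide is that compound 2, which also carries hydroxymethyl on that ring carbon, gives 1430 nM, a number close to that of compound 3. Compound 4 is therefore expected to show no step beyond the scatter, a 1.2-fold higher number from compound 3 to compound 4 (0.08 log units; within the scatter), in this assay. The estimate for compound 4 is 1500 nM, with a range from 600 nM to 4000 nM.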

Compound 4, inhibition constant: 335 nM
For compound 4 the middle estimate is 4.5-fold (0.65 log units) above the measured one; the measured number lies below the stated range.
By their numbers in this assay, from the lowest: compounds 4 and 1 (each within the scatter of the next); then compounds 3 and 2 (each within the scatter of the next).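

Among the compounds shown here, with cyclopentylmethyl held constant, hydroxymethyl in place of ethylcarbamoyl on the saturated ring carbon gives the first clean reading of this change in this assay: a 3.7-fold lower number from compound 3 to compound 4 (0.57 log units; beyond the scatter), a move towards stronger inhibition. The group on the saturated chain carbon also matters with hydroxymethyl in place, since cyclopentyl in place of cyclohexyl gives a 4.3-fold lower number from compound 2 to compound 4 (0.63 log units; beyond the scatter). No available evidence accounts for either step.

The compounds shown leave open whether the gain from hydroxymethyl carries over to compounds with other groups on the aromatic carbon, including the unsubstituted aromatic carbon of compound 1. They also leave open how a carboxylic acid, an aminomethyl or a methylcarbamoyl on that saturated ring carbon would compare with hydroxymethyl.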